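The compounds below may be only part of what the source reports. "The series", "measured", "known", "first", "only" and "open" are said of these compounds alone.

Compound 1 `COc1ccc(S(=O)(=O)N2CCc3cccc(-c4ccc(O)cc4)c32)cc1` is one of three compounds tested in a functional assay on NCI-H460 cells (Homo sapiens) for inhibition, with a stated time of 72 h (a higher number here means a weaker inhibitor, a lower number a stronger inhibitor), and in that assay compound 1 gives 114 nM. This is the lowest of the three numbers. Compound 2 `COc1ccc(S(=O)(=O)n2ccc3cccc(-c4ccc(F)cc4)c32)cc1` differs from compound 1 in several places. In this assay compound 2 gives 212 nM, and this value lies within the scatter of that of compound 1. Compound 3 `COc1ccc(S(=O)(=O)N2CCc3cccc(-c4ccc(N)cc4)c32)cc1` gives 288 nM in this assay, the furthest of the three from compound 1.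

Compound 4 `COc1ccc(S(=O)(=O)N2CCc3cccc(-c4cccc(F)c4)c32)cc1` has not yet been measured. It differs from compound 1 in one place: 3-fluorophenyl in place of 4-hydroxyphenyl on an aromatic carbon. The hydroxy that compound 1 carries is thus gone, and a fluorine takes its position on the ring in a different spot.

Within the data shown here, one measured step bears on this change. Replacing the hydroxy by an amino gave a 2.5-fold higher number from compound 1 to compound 3 (0.40 log units; beyond the scatter), so exchanging that group on its own produced only a modest shift. Compound 2, which also lacks the hydroxy, lies within the scatter of compound 1. On this basis a modest rise in the number, or none beyond the scatter, is expected for compound 4, as a 1.8-fold higher number from compound 1 to compound 4 (0.24 log units; within the scatter). Compound 4 is therefore estimated at 200 nM in this assay, with a range from 90 nM to 450 nM.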

Compound 4, half-maximal inhibitory concentration: 167 nM
The estimate for compound 4 lay 1.2-fold (0.08 log units) above the measured number; measured number inside the range.
By their numbers in this assay, from the lowest: compounds 1, 4, 2 and 3 (each within the scatter of the next, the first and the last beyond it).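

On the core of compound 1, the 3-fluorophenyl group gives a 1.5-fold higher number from compound 1 to compound 4 (0.17 log units; within the scatter) in this assay, so at this aromatic carbon the hydroxy can be lost without a change beyond the scatter. Compound 2 could not show this, as it differs from compound 1 in several places, whereas here the core stays the same and the incoming group has no hydrogen-bond donor or acceptor by the count. The amino compound also gives no separation from the new compound, with a 1.7-fold lower number from compound 3 to compound 4 (0.24 log units; within the scatter), even though compound 1 and compound 3 lie beyond the scatter of each other, and no measurement shown here offers an explanation for any of these numbers.

Since 3-fluorophenyl differs from 4-hydroxyphenyl both in the atom it carries and in where it carries it, this single step cannot tell those two changes apart. How far the position's tolerance extends also remains open, as the compounds shown include no plain phenyl ring, carboxylic acid or longer chain on this carbon, and they offer only one cell line and one read-out.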